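Nitro in Place of Fluoro on a Weak Pair

The compounds below may be only part of what the source reports. "The series", "measured", "known", "first", "only" and "open" are said of these compounds alone.

Compound 1, `COc1cc(Cn2cc(COc3cccc(/C=C4/C(=O)Nc5ccccc54)c3)nn2)cc(OC)c1`, in a functional assay on PC-3 cells (Homo sapiens) for inhibition, read by MTT assay, with a stated time of 48 h; on this read-out lower numbers stand for stronger inhibition and higher numbers for weaker inhibition: 37100 nM.
Compound 2, `O=C1Nc2ccc(F)cc2/C1=C\c1cccc(OCc2cn(Cc3ccccc3)nn2)c1`: > 50000 nM, which is a limit of the assay, not a number.

Compound 2 therefore has no measured number in this assay; its result sits at the limit of > 50000 nM in this assay, at which 1 of the 2 values shown sits, so only an upper bound on its potency is known. Compound 3, `O=C1Nc2ccc([N+](=O)[O-])cc2/C1=C\c1cccc(OCc2cn(Cc3ccccc3)nn2)c1`, differs from compound 2 by nitro in place of fluoro on an aromatic carbon. Among the measured compounds shown here, no measured pair shows this change, so the expected step is small, about none beyond the scatter, in either direction; the estimated step is an at least 1.1-fold lower number from compound 2 to compound 3 (0.04 log units; that floor lies within the scatter). Compound 3 is expected near 45000 nM, with a range from 15000 nM to 150000 nM.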

Compound 3, half-maximal inhibitory concentration: > 50000 nM
Compound 3: a limit, no number (the forecaster's own chance of this, stated with the estimate: 50%); middle value at least 1.1-fold (0.04 log units) from the limit.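

Compound 3 gives > 50000 nM in this assay, which is a limit of the assay and not a number. Compound 2 also stands at a limit, so no step from it to compound 3 can be read: the limit of > 50000 nM in this assay, at which 2 of the 3 values shown sit.

The compounds shown leave open whether nitro or fluoro at this place gives the stronger inhibition.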